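Aryl swap on the triazole nitrogen: outlook for compound 4

The source may hold more compounds than are shown below. What is called first, only, known or untested is meant among the compounds shown, and "the series" means these compounds.

Compound 2 `COc1ccc(-n2nncc2CN2C(=O)C3(C(C#N)=C(N)Oc4c3c3nc5ccccc5nc3c3ccccc43)c3ccccc32)cc1` is known in a functional assay on A549 cells (Homo sapiens) for antiproliferative activity, read by MTT assay, with a stated time of 48 h (a lower number here means a stronger inhibitor, a higher number a weaker inhibitor), only as a limit, > 50000 nM, and so sits at the limit of > 50000 nM in this assay, at which 1 of the 3 values shown sits. Compound 1 `N#CC1=C(N)Oc2c(c3nc4ccccc4nc3c3ccccc23)C12C(=O)N(Cc1cnnn1-c1ccc(Br)cc1)c1ccccc12` gives 44300 nM in this assay. Compound 3 `N#CC1=C(N)Oc2c(c3nc4ccccc4nc3c3ccccc23)C12C(=O)N(Cc1cnnn1-c1cccc(S(N)(=O)=O)c1)c1ccccc12` gives 44200 nM in this assay. With methoxy in place of bromo on an aromatic carbon, the step is an at least 1.1-fold higher number from compound 1 to compound 2 (0.05 log units; that floor lies within the scatter). With 3-sulfamoylphenyl in place of 4-methoxyphenyl on an aromatic nitrogen, the step is an at least 1.1-fold lower number from compound 2 to compound 3 (0.05 log units; that floor lies within the scatter). With 3-sulfamoylphenyl in place of 4-bromophenyl on an aromatic nitrogen, the step is a 1.0-fold lower number from compound 1 to compound 3 (0.00 log units; within the scatter). None of the three aryl changes on this nitrogen moved the read-out beyond the scatter.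

Compound 4 `Cc1ccc(-n2nncc2CN2C(=O)C3(C(C#N)=C(N)Oc4c3c3nc5ccccc5nc3c3ccccc43)c3ccccc32)cc1Cl` differs from compound 2 as follows: 3-chloro-4-methylphenyl in place of 4-methoxyphenyl on an aromatic nitrogen. This is again an exchange of the aryl group on the same aromatic nitrogen, so the expected step is an at least 1.1-fold lower number from compound 2 to compound 4 (0.04 log units; that floor lies within the scatter), nothing beyond the scatter in this assay. Compound 4 is therefore estimated at 45000 nM, in the range 20000 nM to 100000 nM; since that range spans the limit of this assay, a limit-only reading for compound 4 is a real possibility.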

Compound 4, half-maximal inhibitory concentration: > 50000 nM
Compound 4 gave a limit, no number; the forecaster's own chance of this, stated with the estimate: 45%; at least 1.1-fold (0.04 log units) between middle value and limit.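

In this assay, for the compounds shown here, the 3-chloro-4-methylphenyl group, the first aryl group here to carry both a chlorine and a methyl group, extends the flat picture on this aromatic nitrogen, with both readable steps resting on a limit for compound 4: an at least 1.1-fold higher number from compound 1 to compound 4 (0.05 log units; that floor lies within the scatter) and an at least 1.1-fold higher number from compound 3 to compound 4 (0.05 log units; that floor lies within the scatter). The step between compound 2 and compound 4 cannot be read, as both are limits. Compound 4 thus joins compound 2 as a limit-only compound: the limit of > 50000 nM in this assay, at which 2 of the 4 values shown sit.

Still open, going by these compounds, is whether any group on this nitrogen can move the read-out beyond the scatter, for example an aryl ring bearing an amine or a carboxylic acid, or a longer alkyl chain in place of the aryl ring. On these data alone, whether changes elsewhere on the shared core would do so also remains open.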